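A few compounds are considered here, and "the series" means these few. Any claim that something is new, unique, unknown or untested is made for them only; others in the source may bear on it.

Of the compounds shown here, three sharing one core have been measured in a functional assay on HepG2 cells (Homo sapiens) for antiproliferative activity, read by CCK-8 assay, with a stated time of 72 h; on this read-out lower numbers stand for stronger inhibition and higher numbers for weaker inhibition. Compound 1 `COc1ccc(C(=O)Nc2cccc(-c3oc4cc(-c5ccc(F)cc5)ccc4c(=O)c3O)c2)cc1` gives 8420 nM, compound 2 `O=C(Nc1cccc(-c2oc3cc(-c4ccc(F)cc4)ccc3c(=O)c2O)c1)c1ccc(C(F)(F)F)cc1` gives 42700 nM, and compound 3 `Cc1cc(C(=O)Nc2cccc(-c3oc4cc(-c5ccc(F)cc5)ccc4c(=O)c3O)c2)ccc1F` gives 9540 nM. Compound 3 thus holds the second highest of the three numbers: the step of a 1.1-fold higher number from compound 1 to compound 3 (0.05 log units; within the scatter) lies within the scatter, whereas the step of a 4.5-fold lower number from compound 2 to compound 3 (0.65 log units; beyond the scatter) lies beyond it. The change leading to compound 4 `O=C(Nc1cccc(-c2oc3cc(-c4ccc(F)cc4)ccc3c(=O)c2O)c1)c1ccc([N+](=O)[O-])cc1` is 4-nitrophenyl in place of 4-fluoro-3-methylphenyl on a carbonyl carbon. Among the compounds with values here, no measured step carries a nitro group, so the known steps bear on it only indirectly: a 5.1-fold higher number from compound 1 to compound 2 (0.71 log units; beyond the scatter) and a 4.5-fold lower number from compound 2 to compound 3 (0.65 log units; beyond the scatter) show that exchanging the group on this phenyl can move the number by a modest amount in either direction, while a 1.1-fold higher number from compound 1 to compound 3 (0.05 log units; within the scatter) shows that it can also leave the number unchanged. With nothing tying the nitro group to any of these outcomes, a modest step, more likely towards a higher number, is expected for compound 4, a 1.6-fold higher number from compound 3 to compound 4 (0.20 log units; within the scatter). Compound 4 is accordingly estimated at 15000 nM, with a range from 6000 nM to 40000 nM.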

Compound 4, half-maximal inhibitory concentration: 1860 nM
Compound 4: middle estimate off by 8.1-fold (0.91 log units), on the high side, outside the stated range (below it).
By their numbers in this assay, from the lowest: compound 4; then compounds 1 and 3 (each within the scatter of the next); then compound 2.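

Before this result, no group on the phenyl attached to the amide carbonyl had given a number clearly lower than the one seen with 4-methoxyphenyl, but the 4-nitrophenyl group does, with a 4.5-fold lower number from compound 1 to compound 4 (0.66 log units; beyond the scatter) in this assay and a 5.1-fold lower number from compound 3 to compound 4 (0.71 log units; beyond the scatter) as well. Placing nitro where trifluoromethyl stood gives the only large step in the series, a 23-fold lower number from compound 2 to compound 4 (1.36 log units; beyond the scatter), so the same ring carbon can carry groups whose numbers lie far apart. The position can therefore move the number clearly in both directions from the level shared by compound 1 and compound 3.

Nothing available explains why nitro and trifluoromethyl differ so widely. On these data alone, it also remains open whether an amine, a carboxylic acid or a nitrile on this ring carbon would give a number closer to that of compound 4 or that of compound 2.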